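The compounds below may be only part of what the source reports. "The series", "measured", "known", "first", "only" and "open" are said of these compounds alone.

Working notes on a small set of salicylanilide-type amides sharing one core, with a single change tested in two settings.

Of the compounds shown here, three have been measured: compound 1 `O=C(Nc1ccc(NCc2ccccc2)cc1Cl)c1cc(Cl)ccc1O`, compound 2 `O=C(Nc1ccc(NCc2ccc(Cl)cc2)cc1Cl)c1cc(Cl)ccc1O` and compound 3 `O=C(Nc1ccc(NC2CCCC2)cc1)c1cc(Cl)ccc1O`. In an ADME assay on A549 cells (Homo sapiens) for cytotoxicity, read by resazurin assay, with a stated time of 48 h (on this read-out lower numbers stand for higher toxicity in this test and higher numbers for lower toxicity in this test), compound 1 gives 19700 nM. In this assay compound 2 gives 59700 nM, and compound 3 gives 10000 nM. Compound 2 differs from compound 1 in one place, (chloro in place of hydrogen on an aromatic carbon), and that change produced a 3.0-fold higher number from compound 1 to compound 2 (0.48 log units; beyond the scatter). Compound 3 and compound 1 lie within the usual scatter of each other, while compound 2 lies beyond it from compound 3. The difference between the core of compound 3 and that of compound 1 is not broken down here.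

Compound 4 `O=C(Nc1ccc(NC2CCCC2)c(Cl)c1)c1cc(Cl)ccc1O` has not yet been measured. It differs from compound 3 by chloro in place of hydrogen on an aromatic carbon. This is the same kind of change as that from compound 1 to compound 2, but not the same: in compound 2 the chloro sits para to a large group, whereas in compound 4 it sits ortho to a cyclopentylamino group and meta to a large group, on the core of compound 3.

For compound 4 the expected step in this assay is a 2.0-fold higher number from compound 3 to compound 4 (0.30 log units; within the scatter), judged somewhat smaller than the earlier one because a 3.0-fold higher number from compound 1 to compound 2 (0.48 log units; beyond the scatter) was seen at a different place on a different core. Compound 4 is therefore estimated at 20000 nM in this assay, with a likely range from 8000 nM to 50000 nM.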

Compound 4, half-maximal cytotoxic concentration: 16900 nM
Estimate against measurement, compound 4: 1.2-fold (0.07 log units) above, and the stated range covers the measured number.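

In this assay, chloro in place of hydrogen on the core of compound 3 gives a 1.7-fold higher number from compound 3 to compound 4 (0.23 log units; within the scatter), so the change on this core cannot be told apart from repeated measurement of a single compound. Set beside the earlier step, the new one shows no difference larger than two such steps would show by scatter alone, and the series gives no sign that the change behaves differently on the two cores: the same change on two cores in this assay, a 3.0-fold higher number (0.48 log units; beyond the scatter) from compound 1 to compound 2 and a 1.7-fold higher number (0.23 log units; within the scatter) from compound 3 to compound 4, 1.8-fold (0.25 log units) apart, within the scatter of two such steps

For the compounds shown here, this does not show that the step carries over with a fixed size, since it rests on two pairs only, the chloro enters at a different place in each pair, and only the step on the core of compound 1 lies beyond the scatter.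

The compounds shown leave open whether fluoro, methoxy or a nitrile in place of the chloro on the core of compound 3 would give a step beyond the scatter. They also leave open how the number responds when the cyclopentylamino group gives way to a primary amine or a longer chain, or when a carboxylic acid is placed on the shared core.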